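The source may hold more compounds than are shown below. What is called first, only, known or untested is meant among the compounds shown, and "the series" means these compounds.

Working notes on the urea-substituted series. Compound 1 `Cc1cn([C@@H]2O[C@H](CO[Si](C)(C)C(C)(C)C)[C@@]3(OS(=O)(=O)C=C3NC(=O)NC(=O)c3ccccc3)[C@H]2O[Si](C)(C)C(C)(C)C)c(=O)n(C)c1=O` gives in an ADME assay on HEL cells (Homo sapiens) for cytotoxicity, with a stated time of 3 days (a higher number here means that more compound is tolerated, a lower number that less compound is tolerated), only a limit, >= 80000 nM, which is the limit of >= 80000 nM in this assay, at which 1 of the 3 values shown sits. Compound 2 `Cc1cn([C@@H]2O[C@H](CO[Si](C)(C)C(C)(C)C)[C@@]3(OS(=O)(=O)C=C3NC(=O)Nc3ccccc3)[C@H]2O[Si](C)(C)C(C)(C)C)c(=O)n(C)c1=O` gives in this assay a number, 1400 nM. Compound 3 `Cc1cn([C@@H]2O[C@H](CO[Si](C)(C)C(C)(C)C)[C@@]3(OS(=O)(=O)C=C3NC(N)=O)[C@H]2O[Si](C)(C)C(C)(C)C)c(=O)n(C)c1=O` gives in this assay 16000 nM. Within the data shown here, of the two numbers so far, compound 3 stands highest: an 11-fold higher number from compound 2 to compound 3 (1.06 log units; beyond the scatter), and in the other direction an at least 5.0-fold lower number from compound 1 to compound 3 (0.69 log units; beyond the scatter).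

Compound 4 `CCNC(=O)NC1=CS(=O)(=O)O[C@@]12[C@@H](CO[Si](C)(C)C(C)(C)C)O[C@@H](n1cc(C)c(=O)n(C)c1=O)[C@@H]2O[Si](C)(C)C(C)(C)C` is the next member; its difference from compound 3 is ethyl in place of hydrogen on an amide-type nitrogen. The measured steps that bear on this are the two that strip a group from that same nitrogen: an 11-fold higher number from compound 2 to compound 3 (1.06 log units; beyond the scatter) and an at least 5.0-fold lower number from compound 1 to compound 3 (0.69 log units; beyond the scatter), both large and both raising the number when hydrogen takes the place of a ring-bearing group. The move to compound 4 puts a group back on that nitrogen, but an ethyl without a ring, so the number is expected to fall, though by less than the phenyl step: the estimated step is a 2.0-fold lower number from compound 3 to compound 4 (0.30 log units; within the scatter). Compound 4 is thus expected near 8000 nM, within the range 3000 nM to 20000 nM.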

Compound 4, minimum cytotoxic concentration: >= 3200 nM
Compound 4 was reported as a limit; the forecaster's own chance of this, stated with the estimate: 5%; the middle value does not contradict the limit.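

In this assay compound 4 gives only a limit, >= 3200 nM. Ethyl in place of phenyl on the amide-type nitrogen still yields a readable step, an at least 2.2-fold higher number from compound 2 to compound 4 (0.35 log units; beyond the scatter), so a group on that nitrogen does not in itself bring the number down to the level seen with phenyl. The steps from compound 3 and from compound 1 to compound 4 cannot be read, so this result does not show whether ethyl in place of hydrogen changes the number at all.

On these data alone, how far the true number of compound 4 lies beyond its limit remains open, and with it the order of compound 3 and compound 4. Also open, as far as these compounds go, is whether a longer chain such as butyl, or a benzyl group, on the same nitrogen would behave like ethyl or like phenyl.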